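Moving the thiophene attachment point in compound 4

This account rests on a few compounds, and the source may have more. Where it says the series, first, only, none or still open, it means among the compounds named here.

Compound 1 `COC(=O)C1C2CCC3CCC1N(C/C2=C\c1ccc(-c2ccc(C)cc2)cc1)C3` gives 214 nM in an assay with sodium-dependent dopamine transporter (Rattus norvegicus) as the target; a lower number here means a stronger inhibitor, a higher number a weaker inhibitor.
Compound 2 `COC(=O)C1C2CCC3CCC1N(C/C2=C\c1ccc(-c2cccc(Cl)c2)cc1)C3` gives 89 nM in this assay.
Compound 3 `COC(=O)C1C2CCC3CCC1N(C/C2=C\c1ccc(-c2cccs2)cc1)C3` gives 155 nM in this assay.

Compound 3 holds the second highest of the three numbers. Its value sits close to that of compound 1, with a 1.4-fold lower number from compound 1 to compound 3 (0.14 log units; within the scatter), and close to that of compound 2, with a 1.7-fold higher number from compound 2 to compound 3 (0.24 log units; within the scatter); only compound 1 and compound 2 are separated by a step beyond the scatter, a 2.4-fold lower number from compound 1 to compound 2 (0.38 log units; beyond the scatter).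

Compound 4 `COC(=O)C1C2CCC3CCC1N(C/C2=C\c1ccc(-c2ccsc2)cc1)C3` differs from compound 3 by thiophen-3-yl in place of thiophen-2-yl on an aromatic carbon. Within the data shown here, no measured step swaps one thiophene attachment point for another, and the steps that do touch this ring, from compound 1 and from compound 2 to compound 3, stay within the scatter. In this assay, the step from compound 3 to compound 4 is therefore expected to stay within the scatter, a 1.0-fold lower number from compound 3 to compound 4 (0.01 log units; within the scatter). Compound 4 is estimated at 150 nM, within 70 nM to 330 nM.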

Compound 4, inhibition constant: 277 nM
Compound 4: the middle estimate sits 1.8-fold (0.27 log units) below what was measured, within the range that was stated.
By their numbers in this assay, from the lowest: compounds 2, 3, 1 and 4 (each within the scatter of the next, the first and the last beyond it).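

Swapping thiophen-2-yl for thiophen-3-yl keeps the same atoms and only changes how they are joined, and in this assay this stays within the scatter (a 1.8-fold higher number from compound 3 to compound 4 (0.25 log units; within the scatter)). Replacing 4-methylphenyl with thiophen-3-yl also stays within it (a 1.3-fold higher number from compound 1 to compound 4 (0.11 log units; within the scatter)), but replacing 3-chlorophenyl with thiophen-3-yl goes beyond it (a 3.1-fold higher number from compound 2 to compound 4 (0.49 log units; beyond the scatter)), which the same swap to thiophen-2-yl did not do. Nothing available here explains these numbers.

Going by these compounds, whether an amine or a carboxylic acid on the thiophene ring would move the number remains open. So does whether a chlorine there would bring it closer to that of the 3-chlorophenyl compound.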